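This account rests on a few compounds, and the source may have more. Where it says the series, first, only, none or still open, it means among the compounds named here.

Compound 1 `N#CC1CN1C(=O)Nc1ccc(S(N)(=O)=O)cc1`: > 38000 nM
Compound 2 `CNC(=O)N1CC1C#N`: 22000 nM

In a functional assay on A549 cells (Homo sapiens) for inhibition (on this read-out higher numbers stand for weaker inhibition and lower numbers for stronger inhibition), compound 1 reaches only a limit, > 38000 nM, which marks the edge of the assay rather than a measured number (the limit of > 38000 nM in this assay, at which 1 of the 2 values shown sits). In this assay compound 2 gives 22000 nM, a weak inhibition. Compound 3 `N#CC1CN1C(=O)Nc1ccc(F)cc1` is not yet tested and differs from compound 1 by fluoro in place of sulfamoyl on an aromatic carbon. Going by the values given here, no measured pair of compounds carries this change, so the step in this assay is expected to stay within the scatter, with compound 3 estimated at 35000 nM, between 9000 nM and 120000 nM, an expected step of an at least 1.0-fold lower number from compound 1 to compound 3 (0.03 log units; that floor lies within the scatter).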

Compound 3, half-maximal inhibitory concentration: 6200 nM
The estimate for compound 3 lay 5.6-fold (0.75 log units) above the measured number, and the stated range ends above it.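

Going by these compounds alone, at this aromatic carbon, fluoro in place of sulfamoyl brings the first readable step in this assay, with an at least 6.1-fold lower number from compound 1 to compound 3 (0.78 log units; beyond the scatter). The position therefore affects inhibition, and the stronger inhibition comes with the group carrying no hydrogen-bond donors or acceptors. Compound 1 stands only at a limit, so the full size of the step remains unknown: the limit of > 38000 nM in this assay, at which 1 of the 3 values shown sits.

A single swap cannot separate the loss of sulfamoyl from the arrival of fluoro. Other groups on this carbon, such as an amine, a carboxylic acid or chloro, could show which of the two matters.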